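Chloro to Fluoro on the Shared Core

A few compounds are considered here, and "the series" means these few. Any claim that something is new, unique, unknown or untested is made for them only; others in the source may bear on it.

Compound 1 `Cc1ccc(-c2cnc(C(=O)CCCCCCc3ccccc3)o2)nc1`: 2.8 nM
Compound 2 `O=C(CCCCCCc1ccccc1)c1ncc(Cl)o1`: 5 nM

Both compounds were tested in an assay (Rattus norvegicus) for inhibition of Fatty-acid amide hydrolase 1 (Homo sapiens); a lower number here means a stronger inhibitor, a higher number a weaker inhibitor. Compound 1 gives 2.8 nM, and compound 2 gives 5 nM in this assay. Compound 2 stands at the upper end of the two numbers shown, separated from compound 1 only by the step of a 1.8-fold higher number from compound 1 to compound 2 (0.25 log units; within the scatter), which exchanges a 5-methylpyridin-2-yl group for chloro and stays within the scatter.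

Compound 3 `O=C(CCCCCCc1ccccc1)c1ncc(F)o1` has not yet been measured. It differs from compound 2 as follows: fluoro in place of chloro on an aromatic carbon. Going by the values given here, no measured step exchanges one halogen for another. Among the compounds with values here, the only step known, a 1.8-fold higher number from compound 1 to compound 2 (0.25 log units; within the scatter), shows that a far larger exchange at the same place left the number within the scatter, so a small exchange of chloro for fluoro is expected to produce no step beyond the scatter in this assay, with a slight lean toward a higher number. Compound 3 is estimated at 8 nM, with an expected range from 2.5 nM to 25 nM. The expected step is a 1.6-fold higher number from compound 2 to compound 3 (0.20 log units; within the scatter).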

Compound 3, inhibition constant: 30 nM
For compound 3 the middle estimate is 3.8-fold (0.57 log units) below the measured one; the whole stated range lies below it.
By their numbers in this assay, from the lowest: compounds 1 and 2 (each within the scatter of the next); then compound 3.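

At the aromatic carbon next to the ring oxygen, fluoro in place of chloro gives a 6.0-fold higher number from compound 2 to compound 3 (0.78 log units; beyond the scatter) in this assay, so an exchange of one heavy atom for one heavy atom carries the number past the scatter, whereas the far larger exchange in a 1.8-fold higher number from compound 1 to compound 2 (0.25 log units; within the scatter) did not. The position is therefore not indifferent to what it carries, and an 11-fold higher number from compound 1 to compound 3 (1.03 log units; beyond the scatter) confirms that fluoro stands apart from both other groups, so the count of heavy atoms alone does not order these three compounds. Nothing at hand explains why fluoro departs from chloro at this carbon.

The compounds shown leave open whether bromo or iodo at this carbon would stay with chloro, or whether the step seen with fluoro is one point on a wider trend across the halogens. They also leave open where a small group without a halogen, such as methyl or a nitrile, would fall, and whether the same exchange would give a step of this size with a shorter or longer chain on the carbonyl.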